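The source may report more compounds than this note shows. Statements on the series, on what has been measured and on what is new or still open speak of the compounds shown alone.

Compound 3, `Cc1ccc2c(c1)nc(O)n2C1CCN(CC2COc3ccc(F)cc3O2)CC1`, is the compound whose measured number is the lowest of the two reported as plain values in a functional assay on the whole organism with Rattus norvegicus as the target; on this read-out higher numbers stand for an effect only at larger amounts of compound and lower numbers for an effect already at smaller amounts. Compound 3 gives 2.5 mg/kg there. The nearest neighbour is compound 1, `Cc1cccc2c1OCC(CN1CCC(n3c(O)nc4cc(F)ccc43)CC1)O2`; compound 1 gives 8 mg/kg, and the gap between the two lies beyond the usual scatter of this assay. Compound 2, `Oc1nc2cc(F)ccc2n1C1CCN(CC2COc3cc(F)ccc3O2)CC1`, is reported only with a limit of the assay, < 5 mg/kg, and not with a number.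

Compound 4, `Cc1ccc2c(c1)nc(O)n2C1CCN(CC2COc3ccc(Cl)cc3O2)CC1`, differs from compound 3 in one place: chloro in place of fluoro on an aromatic carbon. The halogen that leaves and the one that enters are both single heavy atoms without donor or acceptor character, and the place on the ring is the same.

Going by the values given here, no pair among the measured compounds differs in exactly this way, so there is no measured step to lean on. The change is small in kind, and the expected step from compound 3 to compound 4 is no change at the digits printed from compound 3 to compound 4 (within the scatter), that is, no movement beyond the scatter in either direction. For compound 4, the expected value in this assay is therefore 2.5 mg/kg, within a range from 1.2 mg/kg to 6 mg/kg.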

Compound 4, dose for half-maximal effect: 1 mg/kg
Compound 4: the middle estimate sits 2.5-fold (0.40 log units) above what was measured; measured number below the stated range.
By their numbers in this assay, from the lowest: compound 4; then compound 3; then compound 1.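

In this assay, going by these compounds alone, this change gives the first step that can be read between two compounds differing in one place: a 2.5-fold lower number from compound 3 to compound 4 (0.40 log units; beyond the scatter). It shows that on this aromatic carbon, meta to a fused ring and para to a fused ring, chloro and fluoro are not interchangeable in this read-out, even though each is a single heavy atom with no hydrogen-bond donors or acceptors. This is one pair on one core, so it holds for compound 3 and compound 4 and sets no rule for halogens elsewhere, and nothing given here bears on what lies behind the step.

The compounds shown leave open how other groups at this same place would read, such as bromo, methoxy, trifluoromethyl or an amine, and so whether the number keeps falling beyond chloro or turns back. They also leave open whether chloro in place of fluoro would give a step of similar size on the aromatic ring of compound 1 or on a core without the methyl group of compound 3.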